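A few compounds are considered here, and "the series" means these few. Any claim that something is new, unique, unknown or untested is made for them only; others in the source may bear on it.

Measured so far in an ADME assay on a cell-free system (plasma, Homo sapiens) for protein binding:
- Compound 1 `CO[C@H](C)c1c(NC(=O)Nc2cnc(-n3nccn3)c(Cl)c2)cnc2cc(Cl)nn12`: 97.7%
- Compound 2 `O=C(Nc1cnc(-n2nccn2)c(Cl)c1)Nc1cnc2cc(Cl)nn2c1C1CC1`: > 99%

For compound 2, > 99% is a limit of the assay and not a number. Compound 3 `CO[C@@H](C)c1c(NC(=O)Nc2cnc(-n3nccn3)c(Cl)c2)cnc2cc(Cl)nn12` carries 1-methoxyethyl in place of cyclopropyl on an aromatic carbon. For the measured compounds named here, the one measured step that bears on this is the same swap run the other way: an at least 2.3-fold lower unbound fraction from compound 1 to compound 2 (0.36 log units; beyond the scatter). A step of similar size in the opposite direction, towards more free compound, is therefore expected in this assay. The expected change is an at least 2.3-fold higher unbound fraction from compound 2 to compound 3 (0.36 log units; beyond the scatter). Compound 3 is estimated at 97.7%, with an expected range of 96% to 99%.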

Compound 3, plasma protein binding: 98.3%
The estimate for compound 3 lay 1.4-fold (0.13 log units) (unbound fraction) above the measured number; low and high end bracket the measured number.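

The two drawn configurations of 1-methoxyethyl cannot be told apart in this assay, with a 1.4-fold lower unbound fraction from compound 1 to compound 3 (0.13 log units; within the scatter), and this comparison isolates the stereocentre alone: the fact that compounds 1 and 3 differ only in the configuration as drawn

Compound 2 has only a limit of the assay and not a number, so the step to the other configuration can be given only as a floor, an at least 1.7-fold higher unbound fraction from compound 2 to compound 3 (0.23 log units; that floor lies within the scatter): the limit of > 99% in this assay, at which 1 of the 3 values shown sits.

From the compounds shown here alone, how far compound 2 lies past its limit remains open. So does whether an amine or a carboxylic acid at this position would leave more of the compound free in this assay.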